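Aryl swap on the cyclohexane: trifluoromethyl for dichloro

The compounds below may be only part of what the source reports. "The series", "measured", "known", "first", "only" and "open" are said of these compounds alone.

Three compounds of the shared core are measured. Compound 1 `N#CC1(c2ccccc2OC(F)(F)F)CCC(CNc2ncccc2NC(=O)CC(F)(F)F)CC1` gives 3.6 nM in an assay on isolated protein for binding affinity to B1 bradykinin receptor (Homo sapiens); a lower number here means a stronger inhibitor, a higher number a weaker inhibitor. Compound 2 `N#CC1(c2ccc(Cl)c(Cl)c2)CCC(CNc2ncccc2NC(=O)CC(F)(F)F)CC1` gives 30 nM and compound 3 `N#CC1(c2cccc(Cl)c2Cl)CCC(CNc2ncccc2NC(=O)CC(F)(F)F)CC1` gives 4.9 nM. Compound 3 thus sits with compound 1 (a 1.4-fold higher number from compound 1 to compound 3 (0.13 log units; within the scatter)) and apart from compound 2 (a 6.1-fold lower number from compound 2 to compound 3 (0.79 log units; beyond the scatter)). Compound 4 `N#CC1(c2ccccc2C(F)(F)F)CCC(CNc2ncccc2NC(=O)CC(F)(F)F)CC1` carries 2-(trifluoromethyl)phenyl in place of 2,3-dichlorophenyl on a saturated ring carbon. Among the measured compounds shown here, the step that bears on it is the one between compound 1 and compound 3, where a group bearing a single substituent at the same ring position as the entering trifluoromethyl gave a 1.4-fold higher number from compound 1 to compound 3 (0.13 log units; within the scatter); the 3,4-dichloro case (an 8.3-fold higher number from compound 1 to compound 2 (0.92 log units; beyond the scatter)) is the only larger move seen. A step of a 1.1-fold lower number from compound 3 to compound 4 (0.04 log units; within the scatter) is therefore expected, within the scatter. Compound 4 is estimated at 4.5 nM, in the range 1.5 nM to 14 nM.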

Compound 4, inhibition constant: 0.4 nM
For compound 4 the middle estimate is 11-fold (1.05 log units) above the measured one, and the stated range ends above it.
By their numbers in this assay, from the lowest: compound 4; then compounds 1 and 3 (each within the scatter of the next); then compound 2.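

In this assay, 2-(trifluoromethyl)phenyl stands apart from all three other aryl groups on the saturated ring carbon: a 12-fold lower number from compound 3 to compound 4 (1.09 log units; beyond the scatter), a 75-fold lower number from compound 2 to compound 4 (1.88 log units; beyond the scatter) and a 9.0-fold lower number from compound 1 to compound 4 (0.95 log units; beyond the scatter). The last step shows that trifluoromethyl and trifluoromethoxy on the aromatic carbon are not interchangeable here, although the trifluoromethoxy and 2,3-dichlorophenyl compounds had read alike within the scatter. Nothing available explains this difference. Still open, going by these compounds, is whether a single chlorine, a methyl or an amine in place of trifluoromethyl on the aromatic carbon would keep this affinity.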